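Swapping the aryl group on the amide of a shared core

A few compounds are considered here, and "the series" means these few. Any claim that something is new, unique, unknown or untested is made for them only; others in the source may bear on it.

Compound 1 `O=C(COc1ccc2cc(/C=C3/SC(=O)NC3=O)ccc2c1)Nc1ccc(Br)cc1F` was tested in an assay on isolated protein for inhibition of histone deacetylase 4 (Homo sapiens), with a stated time of 1 h (a lower number here means a stronger inhibitor, a higher number a weaker inhibitor), where compound 1 gives 1900 nM. Within the data shown here, of the two numbers available, this is the highest; the only neighbour is compound 2 `O=C(COc1ccc2cc(/C=C3/SC(=O)NC3=O)ccc2c1)Nc1c(F)cc(F)cc1Br`, which in this assay gives 1100 nM, and the step of a 1.7-fold lower number from compound 1 to compound 2 (0.24 log units; within the scatter) falls within the scatter. Compound 3 `Cc1ccc(NC(=O)COc2ccc3cc(/C=C4/SC(=O)NC4=O)ccc3c2)cc1Cl` has not yet been measured. Its change from compound 1 is 3-chloro-4-methylphenyl in place of 4-bromo-2-fluorophenyl on an amide-type nitrogen. Among the measured compounds shown here, the one measured step that bears on this, the step from compound 1 to compound 2, also exchanged the aryl group on the amide-type nitrogen, and it produced no change beyond the scatter. For the measured compounds named here, with only that step to go on, the expected step of a 1.3-fold lower number from compound 1 to compound 3 (0.10 log units; within the scatter) is likewise a small one, not clearly beyond the scatter in either direction. Compound 3 is therefore expected to give 1500 nM in this assay, with a likely range from 500 nM to 4500 nM.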

Compound 3, half-maximal inhibitory concentration: 1100 nM
The estimate for compound 3 lay 1.4-fold (0.13 log units) above the measured number; low and high end bracket the measured number.
By their numbers in this assay, from the lowest: compounds 2, 3 and 1 (each within the scatter of the next).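

Moving from the 4-bromo-2-fluorophenyl group to 3-chloro-4-methylphenyl on the amide-type nitrogen of the shared core gives a 1.7-fold lower number from compound 1 to compound 3 (0.24 log units; within the scatter) in this assay, and moving from the 2-bromo-4,6-difluorophenyl group to the same 3-chloro-4-methylphenyl gives no change at the digits printed from compound 2 to compound 3 (within the scatter) in that assay. So a third aryl group, which carries chlorine and methyl where the other two carry bromine and fluorine, also stays within the scatter, and all three compounds now read alike at this position. Nothing available explains why these three groups read alike.

All three groups shown are halogen-bearing phenyl rings, so this agreement says nothing about a ring carrying an amine or a carboxylic acid. It also leaves open what a longer chain on the amide-type nitrogen, in place of the aryl group, would do.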